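The source may report more compounds than this note shows. Statements on the series, on what has been measured and on what is new or still open speak of the compounds shown alone.

In a functional assay on MCF7 cells (Homo sapiens) for inhibition, read by resazurin assay, with a stated time of 72 h (on this read-out lower numbers stand for stronger inhibition and higher numbers for weaker inhibition), compound 1 `C=CC1C(=O)N(c2cc(OC)c(OC)c(OC)c2)C1c1ccc(SCC)cc1` gives 181 nM, compound 2 `COc1ccc(C2C(Oc3ccccc3)C(=O)N2c2cc(OC)c(OC)c(OC)c2)cc1` gives 23 nM and compound 3 `COc1ccc(C2C(C3CC3)C(=O)N2c2cc(OC)c(OC)c(OC)c2)cc1` gives 120 nM. Compound 3 therefore lies within the scatter of compound 1 and clearly on the weaker side of compound 2. Compound 4 `C=CC1C(=O)N(c2cc(OC)c(OC)c(OC)c2)C1c1ccc(OC)cc1` carries vinyl in place of cyclopropyl on a saturated ring carbon. One measured step changes this same place: a 5.2-fold higher number from compound 2 to compound 3 (0.72 log units; beyond the scatter), a modest change made by putting cyclopropyl in place of phenoxy. Compound 1 also carries vinyl there and gives 181 nM, although it differs elsewhere. No step beyond the scatter is therefore expected in this assay. The expected step is a 1.1-fold lower number from compound 3 to compound 4 (0.04 log units; within the scatter). For compound 4, the estimated value is 110 nM, with a range of 40 nM to 300 nM.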

Compound 4, half-maximal inhibitory concentration: 17 nM
The estimate for compound 4 lay 6.5-fold (0.81 log units) above the measured number, outside the stated range (below it).
By their numbers in this assay, from the lowest: compounds 4 and 2 (each within the scatter of the next); then compounds 3 and 1 (each within the scatter of the next).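

In this assay, vinyl and cyclopropyl are not interchangeable on this saturated ring carbon, with a 7.1-fold lower number from compound 3 to compound 4 (0.85 log units; beyond the scatter), while vinyl and phenoxy show no real difference, with a 1.4-fold lower number from compound 2 to compound 4 (0.13 log units; within the scatter). Keeping vinyl in place, methoxy in place of ethylsulfanyl on an aromatic carbon gives an 11-fold lower number from compound 1 to compound 4 (1.03 log units; beyond the scatter), so the change on the aromatic ring also matters. Nothing available here explains these results. As far as these compounds go, whether an amine or a propyl chain on the saturated ring carbon would behave like vinyl or like cyclopropyl stays open. So does whether the ethylsulfanyl-to-methoxy step would be similar with phenoxy or cyclopropyl on that carbon.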